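The compounds below may be only part of what the source reports. "The series", "measured", "known", "first", "only" and "open" are said of these compounds alone.

Measured in a functional assay on the whole organism (strain albino) for inhibition, with Rattus norvegicus as the target, read by paw edema, with stated times of 1 h and 2 h, at a dose of 100 mg/kg by the oral route; on this read-out lower numbers stand for less inhibition and higher numbers for more inhibition at the one dose given (going by the name of the read-out):

compound 1 `N#Cc1c(Nc2ccc(Cl)cc2)nc(SCC(=O)Nn2c(COc3ccc(Cl)cc3Cl)nc3ccccc3c2=O)nc1-c1ccccc1` gives 57.9%
compound 2 `N#Cc1c(Nc2ccc(O)cc2)nc(SCC(=O)Nn2c(COc3ccc(Cl)cc3Cl)nc3ccccc3c2=O)nc1-c1ccccc1` gives 59.7%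
compound 3 `N#Cc1c(Nc2ccccc2)nc(SCC(=O)Nn2c(COc3ccc(Cl)cc3Cl)nc3ccccc3c2=O)nc1-c1ccc(Cl)cc1` gives 50.9%

Compound 1 and compound 2 differ by hydroxy in place of chloro on an aromatic carbon, and the step is a number 1.8 percentage points higher from compound 1 to compound 2 (within the scatter). Compound 3 has the same atoms as compound 1 joined differently; the difference between the two cores is not broken down here. Compound 3 gives the lowest of the three numbers, but its gaps to compound 1 and compound 2 both lie within the scatter.

Compound 4 `N#Cc1c(Nc2ccccc2)nc(SCC(=O)Nn2c(COc3ccc(Cl)cc3Cl)nc3ccccc3c2=O)nc1-c1ccc(O)cc1` is not yet measured and differs from compound 3 by hydroxy in place of chloro on an aromatic carbon. This is the same kind of change as from compound 1 to compound 2, here on the 4-chlorophenyl rather than the (4-chlorophenyl)amino. Because a number 1.8 percentage points higher from compound 1 to compound 2 (within the scatter) stayed within the scatter, the step of a number 1.8 percentage points higher from compound 3 to compound 4 (within the scatter) is expected to be small as well. Compound 4 is therefore estimated at 52.7%, between 42% and 63%.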

Compound 4, a percentage reported as inhibition, in the whole organism at one dose (the size of the read-out at that dose, not a potency): 91.2%
Estimate against measurement, compound 4: 38.5 percentage points below, and the stated range ends below it.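

In this assay, 4-hydroxyphenyl in place of 4-chlorophenyl gives a number 40.3 percentage points higher from compound 3 to compound 4 (beyond the scatter). The size of the step from hydroxy in place of chloro does not carry from one core to the other: the same change on two cores in this assay, a number 1.8 percentage points higher (within the scatter) from compound 1 to compound 2 and a number 40.3 percentage points higher (beyond the scatter) from compound 3 to compound 4, 38.5 percentage points apart, beyond the scatter of two such steps

This rests on one pair per core, and the data do not show why the steps part, nor whether the large step would hold for other compounds in the series.

The compounds shown leave open whether the large step belongs to hydroxy itself or would also come with a methoxy or an amine on that aromatic carbon. Also open, going by these compounds, is what a hydroxy on each of the two aromatic groups together would give.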